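The source may report more compounds than this note shows. Statements on the series, on what has been measured and on what is new or still open speak of the compounds shown alone.

Results in an ADME assay on L6 cells (Rattus norvegicus) for cytotoxicity, read by resazurin assay, with a stated time of 72 h; a lower number here means a stronger inhibitor, a higher number a weaker inhibitor:

Compound 1 `N/C(CC(O)c1ccc2ccccc2c1)=N\N=C\c1ccc(Cl)c(Cl)c1`: 100000 nM
Compound 2 `N/C(CC(O)c1ccc2ccccc2c1)=N\N=C\c1ccco1`: "not determined" (no result reported)
Compound 3 `N/C(CC(O)c1ccc2ccccc2c1)=N\N=C\c1ccc(F)cc1F`: 93000 nM

Among the compounds with values here, compound 3 holds the lowest of the two numbers that were obtained, but its only neighbour on the scale, compound 1, lies within the usual scatter of it, as a 1.1-fold lower number from compound 1 to compound 3 (0.03 log units; within the scatter) shows; compound 2 contributes no number, so nothing can be said of how it compares.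

Compound 4 `COc1ccc(/C=N/N=C(\N)CC(O)c2ccc3ccccc3c2)cc1` has not yet been tested in this assay. It differs from compound 3 as follows:
4-methoxyphenyl in place of 2,4-difluorophenyl on a carbon with a double bond to nitrogen

Within the data shown here, the one measured step that bears on a change at this carbon, a 1.1-fold lower number from compound 1 to compound 3 (0.03 log units; within the scatter), was within the scatter, and both measured compounds sit at similarly high values. On that basis no step beyond the scatter is expected from compound 3 to compound 4, and the estimated change is a 1.1-fold higher number from compound 3 to compound 4 (0.03 log units; within the scatter). Compound 4 is therefore expected to give about 100000 nM in this assay, with a plausible range from 50000 nM to 200000 nM.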

Compound 4, half-maximal inhibitory concentration: 69000 nM
Estimate against measurement, compound 4: 1.4-fold (0.16 log units) above; measured number inside the range.
By their numbers in this assay, from the lowest: compounds 4, 3 and 1 (each within the scatter of the next).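

Compounds 1 and 3 compared only halogen-bearing phenyl groups on the carbon with a double bond to nitrogen. Compound 4 extends the comparison to 4-methoxyphenyl, which carries one hydrogen-bond acceptor where 2,4-difluorophenyl carries none, and the step in this assay stays within the scatter (a 1.3-fold lower number from compound 3 to compound 4 (0.13 log units; within the scatter)), as does the step from the 3,4-dichlorophenyl compound (a 1.4-fold lower number from compound 1 to compound 4 (0.16 log units; within the scatter)). Across these three groups, the position therefore shows no change that can be told from the scatter, and nothing measured here offers an explanation for this.

The compounds shown leave open whether an amine or a carboxylic acid on the phenyl group would shift the number beyond the scatter. They also leave open whether replacing the hydroxyl group on the shared core with a methoxy group would do so.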